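This account rests on a few compounds, and the source may have more. Where it says the series, first, only, none or still open, it means among the compounds named here.

Compound 1 `Cc1cccc(-n2nncc2CN2C(=O)C3(C(C#N)=C(N)Oc4c3c3nc5ccccc5nc3c3ccccc43)c3ccccc32)c1` carries a 3-methylphenyl group on the aromatic nitrogen of the shared core. In an ADME assay on HUVEC cells (Homo sapiens) for antiproliferative activity, read by MTT assay, with a stated time of 48 h (on this read-out higher numbers stand for weaker inhibition and lower numbers for stronger inhibition), compound 1 reaches only the limit of the assay, giving > 50000 nM. Compound 2 `CCOc1ccccc1-n1nncc1CN1C(=O)C2(C(C#N)=C(N)Oc3c2c2nc4ccccc4nc2c2ccccc32)c2ccccc21` bears a 2-ethoxyphenyl group on that same nitrogen. In this assay compound 2 likewise stops at the limit of the assay, giving > 50000 nM. The step that the two limits leave unreadable from compound 1 to compound 2 is therefore one whose size cannot be read, since both compounds sit at the limit of > 50000 nM in this assay, at which 2 of the 2 values shown sit. Compound 2 thus stands at that limit and nowhere more exactly.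

Compound 3 `CCOc1ccc(-n2nncc2CN2C(=O)C3(C(C#N)=C(N)Oc4c3c3nc5ccccc5nc3c3ccccc43)c3ccccc32)cc1` is the compound still to be measured. It differs from compound 2 by 4-ethoxyphenyl in place of 2-ethoxyphenyl on an aromatic nitrogen. For the measured compounds named here, the only measured step that bears on this change is the one from compound 1 to compound 2, and it shows neither a size nor a direction. Going by the values given here, no measured step therefore points to a shift in this assay beyond the scatter. Compound 3 is consequently expected to give around 60000 nM, with a range from 20000 nM to 200000 nM, and most probably to be reported again only as a limit. The step that the limit leaves unreadable from compound 2 to compound 3 is accordingly estimated to be small or absent.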

Compound 3, half-maximal inhibitory concentration: > 50000 nM
Compound 3: a limit, no number; the forecaster's own chance of this, stated with the estimate: 85%; the middle value lies beyond the limit too.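

In this assay compound 3 gives > 50000 nM as a limit and not a number. For the compounds shown here, no step among compound 1, compound 2 and compound 3 can therefore be read: the limit of > 50000 nM in this assay, at which 3 of the 3 values shown sit. The compounds shown leave open whether 4-ethoxyphenyl, 2-ethoxyphenyl and 3-methylphenyl differ at all in their effect on this read-out.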